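From Amino to Acetamido at the Assay Limit

The source may hold more compounds than are shown below. What is called first, only, known or untested is meant among the compounds shown, and "the series" means these compounds.

Of the compounds shown here, three have been measured in a functional assay with Rattus norvegicus as the target (on this read-out lower numbers stand for an effect already at smaller amounts and higher numbers for an effect only at larger amounts of compound), and none of them yields a number. Compound 1 `CC(C)(C)c1ccc(C/N=C(\S)NC(c2ccccc2)c2ccc(NS(C)(=O)=O)cc2)cc1` reads > 100000 nM, which is a limit of the assay. Compound 2 `CC(C)C(/N=C(\S)NCc1ccc(C(C)(C)C)cc1)c1ccc(NS(C)(=O)=O)cc1` reads > 100000 nM, which is again a limit. Compound 3 `C[C@@H](/N=C(\S)NCc1ccc(C(C)(C)C)cc1)c1ccc(N)cc1` reads > 100000 nM, also a limit and not a number. The whole record so far is therefore (the limit of > 100000 nM in this assay, at which 3 of the 3 values shown sit).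

Compound 4 `CC(=O)Nc1ccc([C@@H](C)/N=C(\S)NCc2ccc(C(C)(C)C)cc2)cc1` differs from compound 3 in one place, with acetyl in place of hydrogen on a nitrogen on an aromatic ring, or amino to acetamido: acetyl in place of hydrogen on a nitrogen on an aromatic ring. For the measured compounds named here, no measured pair shows what this change does, so the expectation rests on the standing of compound 3 at the limit. No step beyond the usual scatter, in either direction, is expected in this assay. The expected size of the step is a number no higher from compound 3 to compound 4 (the limit leaves the size open). Compound 4 is estimated at 100000 nM, with an expected range from 20000 nM to 200000 nM.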

Compound 4, half-maximal effective concentration: > 100000 nM
Compound 4: no number, only a limit; the forecaster's own chance of this, stated with the estimate: 85%; the middle value sits exactly at the limit.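

In this assay compound 4 reads > 100000 nM, which is a limit and not a number. For the compounds shown here, compound 3 also stands at a limit, so no step between compound 3 and compound 4 can be read. The compounds shown leave open how any structural change affects the read-out, because the record offers no measured number: the limit of > 100000 nM in this assay, at which 4 of the 4 values shown sit.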